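This account rests on a few compounds, and the source may have more. Where it says the series, first, only, none or still open, it means among the compounds named here.

Within the data shown here, in a physicochemical assay for lipophilicity (on this read-out higher numbers stand for higher lipophilicity and lower numbers for lower lipophilicity), compound 3 `CN1CCN(c2cc(C(F)(F)F)ccc2[C@H]2CCOc3cc(S(=O)(=O)Nc4nccs4)ccc32)CC1` gives 2.1, the lowest of the three numbers so far. Compound 4 `Cn1nccc1-c1cc(C(F)(F)F)ccc1[C@H]1CCOc2cc(S(=O)(=O)Nc3nccs3)ccc21` differs from compound 3 in one place, where 1-methyl-1H-pyrazol-5-yl stands in place of 4-methylpiperazin-1-yl on an aromatic carbon: 1-methyl-1H-pyrazol-5-yl in place of 4-methylpiperazin-1-yl on an aromatic carbon. Among the measured compounds shown here, no measured pair shows this change alone, so any expectation is rough. Compound 1 `O=S(=O)(Nc1ncccn1)c1ccc2c(c1)OCC[C@@H]2c1ccc(C(F)(F)F)cc1-c1ccc(F)nc1`, at 2.8, and compound 2 `Cc1nc(-c2cc(C(F)(F)F)ccc2[C@H]2CCOc3cc(S(=O)(=O)Nc4cccc(F)n4)ccc32)co1`, at 4, also carry an aromatic ring at that place, though they differ elsewhere too, and both lie higher than compound 3 by more than the scatter. An upward move beyond the scatter is therefore expected, estimated as a number 0.90 log units higher from compound 3 to compound 4 (beyond the scatter). For compound 4 the estimated value is 3, with an expected range from 2.4 to 3.6.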

Compound 4, distribution coefficient: 2.2
Beside the measured number, compound 4's estimate is 0.80 log units above it; the whole stated range lies above it.
By their numbers in this assay, from the lowest: compounds 3 and 4 (each within the scatter of the next); then compound 1; then compound 2.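

In this assay, placing 1-methyl-1H-pyrazol-5-yl in place of 4-methylpiperazin-1-yl on this aromatic carbon gives a number 0.10 log units higher from compound 3 to compound 4 (within the scatter) with the rest of the molecule unchanged. This single change shows that a five-membered aromatic ring and a six-membered non-aromatic ring at this position can give values that cannot be told apart. No available data explain this result.

From the compounds shown here alone, it remains open whether a carboxylic acid or a longer chain at this place would give a clearly different number, and whether this exchange would behave the same way in other compounds.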